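The compounds below may be only part of what the source reports. "The series", "measured", "known", "first", "only" and "open" are said of these compounds alone.

Measured so far:
Compound 1 `Cc1ccc(OCC(=O)N(Cc2cccs2)c2ccn(C)n2)cc1` — in an assay on HEK293 cells for agonist activity at transient receptor potential cation channel subfamily M member 8 (Homo sapiens), read by fluorescence and calcium flux, with a stated time of 15 min (a lower number here means that less compound is needed, a higher number that more compound is needed for the effect), compound 1 gives 855 nM.
Compound 2 `Cc1ccc(OCC(=O)N(Cc2cccs2)c2ccncc2)cc1` — in this assay compound 2 gives 52 nM.

Among the measured compounds shown here, compound 2 stands at the lowest of the two numbers; the only other measured compound lies a full step away, a 16-fold lower number from compound 1 to compound 2 (1.22 log units; beyond the scatter).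

Compound 3 `Cc1ccc(OCC(=O)N(Cc2cccs2)c2ccccc2)cc1` is not yet measured. The change from compound 2 is phenyl in place of pyridin-4-yl on an amide-type nitrogen. For the measured compounds named here, only one measured step bears on this position, a 16-fold lower number from compound 1 to compound 2 (1.22 log units; beyond the scatter), and it shows that the group on the amide-type nitrogen can shift the number strongly. Going by the values given here, that step exchanges one hetero-aromatic ring for another; no measured compound carries a ring of carbon only at this place, so the direction of the new step is not fixed by the data. Given the weight of this position, some rise in the number is expected, with wide uncertainty. Compound 3 is estimated at 150 nM, range 40 nM to 700 nM. The expected step is a 2.9-fold higher number from compound 2 to compound 3 (0.46 log units; beyond the scatter).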

Compound 3, half-maximal effective concentration: 23 nM
Estimate against measurement, compound 3: 6.5-fold (0.81 log units) above, and the stated range ends above it.
By their numbers in this assay, from the lowest: compound 3; then compound 2; then compound 1.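

In this assay the ring on the amide-type nitrogen does not need a ring nitrogen: phenyl in place of pyridin-4-yl gives a 2.3-fold lower number from compound 2 to compound 3 (0.35 log units; beyond the scatter), so a six-membered aromatic ring of carbon only is accepted at this place and compound 3 holds the lowest number of the three. Phenyl in place of 1-methyl-1H-pyrazol-3-yl gives a 37-fold lower number from compound 1 to compound 3 (1.57 log units; beyond the scatter), the widest span yet seen at this position, and the order here now runs phenyl, then pyridin-4-yl, then 1-methyl-1H-pyrazol-3-yl. No measurement is at hand that would explain this order.

Still open, as far as these compounds go, is how the number responds to a phenyl ring carrying a fluoro or methoxy group, or to a saturated ring such as cyclohexyl, at this place. Also open, from the compounds shown here alone, is whether the same order of rings holds once another part of the shared core changes.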